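Swapping piperidin-1-yl for piperazin-1-yl on compound 3

The source may report more compounds than this note shows. Statements on the series, on what has been measured and on what is new or still open speak of the compounds shown alone.

Measured in a functional assay on Jurkat cells (Homo sapiens) for cytotoxicity, with a stated time of 48 h; on this read-out lower numbers stand for stronger inhibition and higher numbers for weaker inhibition:
- compound 1 `CCOC(=O)CC1C(C(=O)OCC)=C(N)Oc2ccccc21` gives 91400 nM
- compound 2 `CCCc1ccc2c(c1)C(CC(=O)OCC)C(C(=O)OCC)=C(N)O2` gives 57300 nM
- compound 3 `CCOC(=O)C1=C(N)Oc2ccc(-c3ccccc3)cc2C1CC(=O)N1CCCCC1` gives 58500 nM

All three values lie within the usual scatter of one another, so compound 3 (58500 nM) has no clear rank among them. Compound 4 `CCOC(=O)C1=C(N)Oc2ccc(-c3ccccc3)cc2C1CC(=O)N1CCNCC1` carries piperazin-1-yl in place of piperidin-1-yl on a carbonyl carbon. Going by the values given here, the only measured step, a 1.6-fold lower number from compound 1 to compound 2 (0.20 log units; within the scatter), puts propyl in place of hydrogen on an aromatic carbon. Among the compounds with values here, no measured step changes the group on the carbonyl carbon, so it offers only weak guidance. In this assay the estimated step is therefore a 1.0-fold higher number from compound 3 to compound 4 (0.01 log units; within the scatter), with no direction expected beyond the scatter. For compound 4 the expected value is 60000 nM, with an estimated range from 25000 nM to 140000 nM.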

Compound 4, half-maximal inhibitory concentration: 53700 nM
Beside the measured number, compound 4's estimate is 1.1-fold (0.05 log units) above it; the range from low to high includes it.
By their numbers in this assay, from the lowest: compounds 4, 2, 3 and 1 (each within the scatter of the next).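

In this assay, the group on the carbonyl carbon now has a measured step of its own: a 1.1-fold lower number from compound 3 to compound 4 (0.04 log units; within the scatter). Piperazin-1-yl brings one hydrogen-bond donor and one hydrogen-bond acceptor that piperidin-1-yl lacks, with the same number of heavy atoms, yet this swap does not separate the two compounds beyond the scatter. No available evidence offers an explanation for this result.

As far as these compounds go, whether morpholin-4-yl or an open-chain amine such as dimethylamino on this carbonyl carbon would move the number beyond the scatter remains open.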